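The compounds below may be only part of what the source reports. "The series", "measured", "known", "first", "only" and "open" are said of these compounds alone.

Measured in a functional assay on MCF7 cells (Homo sapiens) for antiproliferative activity, read by luminescence, with a stated time of 24 h; on this read-out higher numbers stand for weaker inhibition and lower numbers for stronger inhibition:
- compound 1 `Cc1cc(C)c2c(c1C)OC(C)(COc1ccc(/C=C3\SC(=O)NC3=O)cc1)CC2`: 12500 nM
- compound 2 `CC(=O)NCCNC(=O)CCC(=O)Oc1c(C)c(C)c2c(c1C)CCC(C)(COc1ccc(/C=C3\SC(=O)NC3=O)cc1)O2`: > 50000 nM (a limit of the assay, not a number)
- compound 3 `Cc1c(C)c2c(c(C)c1OC(=O)CCCC[C@@H]1SC[C@@H]3NC(=O)N[C@@H]31)CCC(C)(COc1ccc(/C=C3\SC(=O)NC3=O)cc1)O2`: 11200 nM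

Compound 3 gives 11200 nM, which lies within the scatter of compound 1 at 12500 nM. The two therefore cannot be ranked against each other. Compound 2 is the only one of the set that stops at a limit.

The next change leads to compound 4 `Cc1c(C)c2c(c(C)c1OC(=O)CCCCCCCN)CCC(C)(COc1ccc(/C=C3\SC(=O)NC3=O)cc1)O2`, which has not yet been measured. It is described by a group of 4 heavy atoms (3 carbon, 1 nitrogen; no ring) in place of a group of 9 heavy atoms (5 carbon, 2 nitrogen, 1 oxygen, 1 sulfur; one five-membered non-aromatic ring with 1 hetero atom, one five-membered non-aromatic ring with 2 hetero atoms), on a saturated chain carbon, four bonds along the chain from a carbonyl carbon. The group that leaves carries two five-membered non-aromatic rings, while the group that enters, 3-aminopropyl, has no ring.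

Among the measured compounds shown here, only one measured step bears on this change: an at least 4.4-fold lower number from compound 2 to compound 3 (0.64 log units; beyond the scatter). It shows that exchanging a group on this chain can move the number beyond the scatter. However, that step brought in a different group, so it gives no direction for compound 4. With no direction to go on, no shift beyond the scatter is expected in this assay, although the uncertainty is wide on both sides. The expected change is a 1.1-fold lower number from compound 3 to compound 4 (0.05 log units; within the scatter). For compound 4 the estimated value is 10000 nM, with an expected range of 3000 nM to 40000 nM.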

Compound 4, half-maximal inhibitory concentration: 3200 nM
Compound 4: middle estimate off by 3.1-fold (0.49 log units), on the high side; measured number inside the range.
By their numbers in this assay, from the lowest: compound 4; then compounds 3 and 1 (each within the scatter of the next). At a limit, above all of these: compound 2.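

In this assay, ((7-aminoheptyl)carbonyl)oxy is the first group shown on this aromatic carbon to move the number beyond the scatter relative to hydrogen, with a 3.9-fold lower number from compound 1 to compound 4 (0.59 log units; beyond the scatter). The change on the chain also matters: putting 3-aminopropyl, which has no ring, in place of the group with two five-membered non-aromatic rings gives a 3.5-fold lower number from compound 3 to compound 4 (0.54 log units; beyond the scatter), so those rings are not required to reach this level of inhibition in this set. The largest step, an at least 15-fold lower number from compound 2 to compound 4 (1.19 log units; beyond the scatter), is only a minimum, as one end of it is a limit of the assay and not a number: the limit of > 50000 nM in this assay, at which 1 of the 4 values shown sits.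

The compounds shown do not separate the contribution of the terminal amine from that of the chain carrying it; a chain of the same length ending in a carboxylic acid or a hydroxyl group, together with shorter and longer chains ending in an amine, would be needed to tell these apart. On these data alone, it also remains open whether the step would hold with an amide in place of the carbonyl-oxy link to the aromatic carbon.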